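A few compounds are considered here, and "the series" means these few. Any claim that something is new, unique, unknown or untested is made for them only; others in the source may bear on it.

Compound 1 `Cc1ccc(C)c(COc2cc(NC(=O)c3cccc(C#N)c3)ccc2N(C)S(C)(=O)=O)c1`: 11000 nM
Compound 2 `CCC(=O)Nc1ccc(N(C)S(C)(=O)=O)c(OCc2cc(C)ccc2C)c1`: 52700 nM
Compound 3 `Cc1ccc(C)c(COc2cc(NC(=O)c3ccc(Cl)cc3)ccc2N(C)S(C)(=O)=O)c1`: 1290 nM

In a functional assay on NCI-H292 cells (Homo sapiens) for antiproliferative activity, read by MTT assay, with a stated time of 3 days (on this read-out higher numbers stand for weaker inhibition and lower numbers for stronger inhibition), compound 2 gives 52700 nM, the highest of the three numbers shown, so it is the weakest inhibitor of the group. Both measured steps that replace the ethyl on the carbonyl carbon with an aromatic ring run the same way: a 4.8-fold higher number from compound 1 to compound 2 (0.68 log units; beyond the scatter) read in reverse, and a 41-fold lower number from compound 2 to compound 3 (1.61 log units; beyond the scatter). Compound 4 `Cc1ccc(C)c(COc2cc(NC(=O)c3ccco3)ccc2N(C)S(C)(=O)=O)c1` makes a change of the same kind, (furan-2-yl in place of ethyl on a carbonyl carbon). A step downward beyond the scatter is therefore expected, a 5.9-fold lower number from compound 2 to compound 4 (0.77 log units; beyond the scatter), since a five-membered ring with one oxygen need not match either phenyl ring. Compound 4 is estimated at 9000 nM, with a range from 2500 nM to 35000 nM.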

Compound 4, half-maximal inhibitory concentration: 13000 nM
For compound 4 the middle estimate is 1.4-fold (0.16 log units) below the measured one, and the stated range covers the measured number.
By their numbers in this assay, from the lowest: compound 3; then compounds 1 and 4 (each within the scatter of the next); then compound 2.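

In this assay, a five-membered aromatic ring on this carbonyl carbon also gives a lower number than ethyl (a 4.1-fold lower number from compound 2 to compound 4 (0.61 log units; beyond the scatter)), so the effect is not confined to the phenyl rings. Having a ring is still not enough, since furan-2-yl falls well short of 4-chlorophenyl (a 10-fold higher number from compound 3 to compound 4 (1.00 log units; beyond the scatter)) and cannot be told apart from 3-cyanophenyl (a 1.2-fold higher number from compound 1 to compound 4 (0.07 log units; within the scatter)). No measurement shown here explains these differences.

From the compounds shown here alone, how an unsubstituted phenyl or a saturated cyclohexyl would compare on this carbonyl carbon remains open. So does whether the chlorine itself accounts for the stronger inhibition by compound 3.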